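The compounds below may be only part of what the source reports. "The series", "measured", "known", "first", "only" and "open" are said of these compounds alone.

In a functional assay on SK-BR-3 cells (Homo sapiens) for cytotoxicity, read by sulforhodamine B assay, with a stated time of 48 h (on this read-out higher numbers stand for weaker inhibition and lower numbers for stronger inhibition), compound 1 `CO[C@@H]1CC=C2NN(c3ccc(C)cc3)C(=O)CC[C@]2(c2ccccc2)O1` gives 2700 nM, compound 2 `CO[C@@H]1CC=C2NN(c3ccc([N+](=O)[O-])cc3)C(=O)CC[C@]2(c2ccccc2)O1` gives 7700 nM, and compound 3 `CO[C@@H]1CC=C2N(c3ccc([N+](=O)[O-])cc3)C(=O)C[C@]2(c2ccccc2)O1` gives 6300 nM. Compound 3 thus holds the second highest of the three numbers: its value and that of compound 2 lie within the usual scatter of each other, while compound 1 sits lower by a margin that exceeds the scatter. Compound 4 `CO[C@@H]1CC=C2N(c3c[nH]c4ccccc34)C(=O)C[C@]2(c2ccccc2)O1` differs from compound 3 by 1H-indol-3-yl in place of 4-nitrophenyl on an amide-type nitrogen in a ring. For the measured compounds named here, the only single-point step measured, a 2.9-fold higher number from compound 1 to compound 2 (0.46 log units; beyond the scatter), shows a modest shift from swapping one group on the aromatic ring; no measured step replaces the whole ring, so this guide is loose. A modest change is expected, a 1.8-fold lower number from compound 3 to compound 4 (0.26 log units; within the scatter), most likely toward a lower number. Compound 4 is therefore estimated at 3500 nM, with a range from 1200 nM to 10000 nM.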

Compound 4, half-maximal inhibitory concentration: 2300 nM
Compound 4: the middle estimate sits 1.5-fold (0.18 log units) above what was measured; the measured number falls inside the stated range.
By their numbers in this assay, from the lowest: compounds 4 and 1 (each within the scatter of the next); then compounds 3 and 2 (each within the scatter of the next).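

On the amide-type nitrogen, replacing the whole group, not just one substituent on an aromatic ring, registers in this assay as a 2.7-fold lower number from compound 3 to compound 4 (0.44 log units; beyond the scatter) and so moves toward stronger inhibition. This position therefore accepts 1H-indol-3-yl, with its two aromatic rings, in place of 4-nitrophenyl without any loss. Nothing available explains the shift.

The change removes the nitro group and adds the second ring and a hydrogen-bond donor all at once, so the step cannot be assigned to any one of these. A naphthyl group, with two aromatic rings but no ring nitrogen, would help separate them.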